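The source may report more compounds than this note shows. Statements on the series, on what has been measured and on what is new or still open speak of the compounds shown alone.

In an ADME assay on HepG2 cells (Homo sapiens) for cytotoxicity, read by MTT assay, with a stated time of 48 h (a higher number here means that more compound is tolerated, a lower number that less compound is tolerated), compound 1 `CCS(=O)(=O)Nc1ccc2c(c1)/C(=C(/Nc1ccc(C)cc1)c1ccccc1)C(=O)N2` gives 3.1 uM, a measured number. Compound 2 `CC/C(Nc1ccc(CN2CCCCC2)cc1)=C1/C(=O)Nc2ccc(NS(=O)(=O)CC)cc21` gives > 6 uM, which is a limit of the assay and not a number. Compound 3 `CC(=O)Nc1ccc2c(c1)/C(=C(/Nc1ccc(CN3CCCCC3)cc1)c1ccccc1)C(=O)N2` gives > 6 uM, which is also a limit and not a number. Compound 2 therefore stands at the limit of > 6 uM in this assay, at which 2 of the 3 values shown sit, with no exact value of its own.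

Compound 4 `CCS(=O)(=O)Nc1ccc2c(c1)/C(=C(\C)Nc1ccc(CN3CCCCC3)cc1)C(=O)N2` has yet to be measured in this assay. It differs from compound 2 in one place: hydrogen in place of methyl on a saturated chain carbon bound to a double-bonded chain carbon. In words, hydrogen stands in place of methyl on a saturated chain carbon bound to a double-bonded chain carbon, so that ethyl becomes methyl. For the measured compounds named here, no two measured compounds differ in only one place, so the data give no direct measure of what such a change does.

With nothing to suggest a larger shift, no change beyond the usual scatter is expected, and no direction is favoured. The estimated step that the limit leaves unreadable from compound 2 to compound 4 is accordingly expected to stay within that scatter. This expectation starts from compound 2 and its limit of > 6 uM. A plain limit is also a likely outcome for the new measurement. For compound 4 the expected value is 8 uM, with an estimated range from 4 uM to 16 uM.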

Compound 4, half-maximal toxic concentration: > 6 uM
Compound 4 was reported as a limit (the forecaster's own chance of this, stated with the estimate: 65%); the middle value does not contradict the limit.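

In this assay compound 4 gives > 6 uM, a limit and not a number. Compound 2 gives > 6 uM, also a limit, and the step between compound 2 and compound 4 cannot be read. The compounds shown leave open whether the change from ethyl to methyl alters the tolerated concentration at all.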